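Swapping the pyridine substituent on a fused pyrazole core

This account rests on a few compounds, and the source may have more. Where it says the series, first, only, none or still open, it means among the compounds named here.

This set is built on one shared core, seen in compound 1 `CC(C)(C)c1cc2n(n1)CCN(C(=O)c1ccc3ccccc3c1)C2`, where a tert-butyl group sits on the core and a naphthoyl amide caps the ring nitrogen. In a functional assay on HEK293 cells for negative allosteric modulation of metabotropic glutamate receptor 5 (Homo sapiens), read by calcium flux, with a stated time of 20 min (a lower number here means a stronger inhibitor, a higher number a weaker inhibitor), compound 1 gives 477 nM. Compound 2 `O=C(c1cccc(Cl)c1)N1CCn2nc(-c3ccccn3)cc2C1` carries a plain pyridin-2-yl group on the core and a 3-chlorobenzoyl amide, and in this assay compound 2 gives 176 nM. Compound 3 `Cc1cccnc1-c1cc2n(n1)CCN(C(=O)c1ccccc1)C2` keeps a benzoyl amide and bears a 3-methylpyridin-2-yl group on the core. For compound 3 this assay reports only a limit, > 10000 nM, so no exact number is known; this is the limit described by the limit of > 10000 nM in this assay, at which 1 of the 3 values shown sits, at which one of the three values stands.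

Compound 4 `O=C(c1ccccc1)N1CCn2nc(-c3ccc(Cl)cn3)cc2C1` is the next step: 5-chloropyridin-2-yl in place of 3-methylpyridin-2-yl on an aromatic carbon of the five-membered ring, next to the ring nitrogen. Going by the values given here, no measured pair differs in just this way. Because compound 2, with its unsubstituted pyridin-2-yl group, gives 176 nM, a return to a measurable number is expected, with the step from compound 3 to compound 4 estimated as an at least 8.3-fold lower number from compound 3 to compound 4 (0.92 log units; beyond the scatter), beyond the usual scatter. For compound 4 the expected value in this assay is 1200 nM, within a range of 200 nM to 8000 nM.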

Compound 4, half-maximal inhibitory concentration: 201 nM
Estimate against measurement, compound 4: 6.0-fold (0.78 log units) above; measured number inside the range.
By their numbers in this assay, from the lowest: compounds 2 and 4 (each within the scatter of the next); then compound 1. At a limit, above all of these: compound 3.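

With the benzoyl amide held fixed, replacing 3-methylpyridin-2-yl with 5-chloropyridin-2-yl on this aromatic carbon gives an at least 49-fold lower number from compound 3 to compound 4 (1.69 log units; beyond the scatter) in this assay, so the group here can by itself carry a compound from a limit to a measured number, which compounds 1, 2 and 3 could not show, as each differs from the others in more than one place. As far as these compounds go, compound 3 stands only at a limit, > 10000 nM, and the step is therefore a minimum whose true size is unknown: the limit of > 10000 nM in this assay, at which 1 of the 4 values shown sits. The two groups match in heavy atoms, hydrogen-bond donors, hydrogen-bond acceptors and net charge, so these counts do not separate a compound at the limit from one with a measured number.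

The swap removes a methyl group and adds a chlorine in one move, and compound 2 differs from compound 4 in two places, so the compounds shown cannot tell which of the two changes matters. Also open, from the compounds shown here alone, is how this position would respond to a pyridine ring carrying a methoxy group or a nitrile, or to a phenyl ring in place of the pyridine.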